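Swapping aminoamino for (cyanomethyl)sulfanyl on the shared core

A few compounds are considered here, and "the series" means these few. Any claim that something is new, unique, unknown or untested is made for them only; others in the source may bear on it.

Measured so far in a functional assay on HeLa cells (Homo sapiens) for antiproliferative activity, read by MTT assay, with a stated time of 48 h; a higher number here means a weaker inhibitor, a lower number a stronger inhibitor
- compound 1 `Cc1ccc(-c2nc(NN)c3cc(Cl)ccc3n2)cc1` gives 3.98 ug/mL
- compound 2 `Cc1ccc(-c2nc(NOC(=O)c3ccccc3)c3cc(Cl)ccc3n2)cc1` gives 5.18 ug/mL

Going by the values given here, compound 1 stands within the scatter of compound 2, and these are the only two numbers at hand. Compound 3 `Cc1ccc(-c2nc(SCC#N)c3cc(Cl)ccc3n2)cc1` has not yet been measured. It carries (cyanomethyl)sulfanyl in place of aminoamino on an aromatic carbon, and the change counts as (cyanomethyl)sulfanyl in place of aminoamino on an aromatic carbon with the rest of the structure the same. Among the compounds with values here, the one measured step is a 1.3-fold higher number from compound 1 to compound 2 (0.11 log units; within the scatter) and it bears only loosely, since it keeps the nitrogen on the core. Within the data shown here, no measured step replaces the whole aminoamino group. On this thin evidence, no step beyond the scatter is expected in this assay for compound 3, and the expected step is a 1.3-fold higher number from compound 1 to compound 3 (0.10 log units; within the scatter) as a rough estimate. For compound 3 the estimated value is 5 ug/mL with an expected range from 2.2 ug/mL to 12 ug/mL.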

Compound 3, half-maximal inhibitory concentration: 3.76 ug/mL
Beside the measured number, compound 3's estimate is 1.3-fold (0.12 log units) above it; low and high end bracket the measured number.
By their numbers in this assay, from the lowest: compounds 3, 1 and 2 (each within the scatter of the next).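

Going by these compounds alone, compound 3 is the first case in which the whole aminoamino group leaves the aromatic carbon, and in this assay the exchange gives a 1.1-fold lower number from compound 1 to compound 3 (0.02 log units; within the scatter) and no measurable shift. At this position, then, (cyanomethyl)sulfanyl, with 4 heavy atoms, a triple bond and 0 hydrogen-bond donors, stands in for aminoamino without moving the number beyond the scatter, so a nitrogen on this carbon is not required for activity in this pair. No measurement at hand offers an explanation for this result.

The compounds shown leave open whether the position stays this permissive for other groups, such as a carboxylic acid, a morpholine or a longer alkylsulfanyl chain. They also leave open whether the match between compound 1 and compound 3 extends to other cell lines.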